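Changing One Amide Group on Compound 2

A few compounds are considered here, and "the series" means these few. Any claim that something is new, unique, unknown or untested is made for them only; others in the source may bear on it.

In a functional assay on A549 cells (Homo sapiens) for inhibition, read by MTT assay, with a stated time of 72 h (on this read-out higher numbers stand for weaker inhibition and lower numbers for stronger inhibition), compound 1 `C/C=C\C(=O)Nc1cc(Nc2nc3c(c(-c4cn(C)c5ccc(F)cc45)n2)CSCC3)c(OC)cc1N(C)CCN(C)C` gives 5310 nM, while compound 2 `C=C(Cl)C(=O)Nc1cc(Nc2nc3c(c(-c4cn(C)c5ccccc45)n2)CSCC3)c(OC)cc1N(C)CCN(C)C` gives 716 nM, the lower of the two numbers and a gap beyond the usual scatter. Compound 3 `COc1cc(N(C)CCN(C)C)c(NC(=O)/C=C\C(C)C)cc1Nc1nc2c(c(-c3cn(C)c4ccccc34)n1)CSCC2` keeps the core of compound 2 but swaps one group: 3-methylbut-1-en-1-yl in place of 1-chloroethenyl on a carbonyl carbon. Here 3-methylbut-1-en-1-yl replaces 1-chloroethenyl on a carbonyl carbon. The expectation leans on compound 1, which also lacks the 1-chloroethenyl group and gives 5310 nM. The expected change is a rise towards weaker inhibition, estimated as a 4.2-fold higher number from compound 2 to compound 3 (0.62 log units; beyond the scatter). For compound 3 the estimated value is 3000 nM, with an expected range of 900 nM to 9000 nM.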

Compound 3, half-maximal inhibitory concentration: 788 nM
For compound 3 the middle estimate is 3.8-fold (0.58 log units) above the measured one; the measured number lies below the stated range.
By their numbers in this assay, from the lowest: compounds 2 and 3 (each within the scatter of the next); then compound 1.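

In this assay the change on the carbonyl carbon, with the rest of the molecule held the same, gives a 1.1-fold higher number from compound 2 to compound 3 (0.04 log units; within the scatter) and the two numbers cannot be told apart. For the compounds shown here, compound 1 and compound 2 differ in more than one place, so only this new pair isolates the group, and 3-methylbut-1-en-1-yl serves here as well as 1-chloroethenyl, even without the chlorine. Nothing shown explains why the two groups match. Still open, on these data alone, is whether the double bond matters, which a saturated chain such as propyl on the carbonyl carbon would address. Also open, as far as these compounds go, is how a chain carrying a dimethylamino group would read.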